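Swapping the sulfur-bearing group on a shared core

The compounds below may be only part of what the source reports. "The series", "measured", "known", "first", "only" and "open" are said of these compounds alone.

In a functional assay on HCC827 cells (Homo sapiens) for antiproliferative activity, read by MTT assay, with a stated time of 72 h (on this read-out lower numbers stand for stronger inhibition and higher numbers for weaker inhibition), compound 2 (`CN1CCN(c2ccc(Nc3ncc4nc([S+]([O-])Cc5ccccc5)n(C5CCOCC5)c4n3)cc2)CC1`) gives 433 nM. Compound 1 (`CN1CCN(c2ccc(Nc3ncc4nc([S+]([O-])c5ccccc5)n([C@H]5CC[C@H](O)CC5)c4n3)cc2)CC1`) gives 268 nM and compound 3 (`CN1CCN(c2ccc(Nc3ncc4nc([S+]([O-])c5ccccc5)n(CC5CC5)c4n3)cc2)CC1`) gives 838 nM, and compound 2 lies within the usual scatter of each of them. Compound 4 (`CN1CCN(c2ccc(Nc3ncc4nc(SCc5cccnc5)n(C5CCOCC5)c4n3)cc2)CC1`) has not yet been measured. It differs from compound 2 in one place: a group of 8 heavy atoms (6 carbon, 1 nitrogen, 1 sulfur; one six-membered aromatic ring with 1 hetero atom) in place of a group of 9 heavy atoms (7 carbon, 1 oxygen, 1 sulfur; one six-membered aromatic ring of carbon only), on an aromatic carbon. The entering group is ((pyridin-3-yl)methyl)sulfanyl, and it sits on an aromatic carbon between two ring nitrogen atoms.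

Within the data shown here, the only measured step, a 3.1-fold higher number from compound 1 to compound 3 (0.50 log units; beyond the scatter), is modest and beyond the scatter. It comes from cyclopropylmethyl in place of 4-hydroxycyclohexyl on an aromatic nitrogen, which is a different place, so it bears only indirectly on this change. Among the measured compounds shown here, no measured compound carries the entering group, and the data favour no direction. In this assay, the expected change is therefore none beyond the scatter, with an estimated 1.1-fold lower number from compound 2 to compound 4 (0.03 log units; within the scatter). The estimated value for compound 4 is 400 nM, with an expected range of 130 nM to 1200 nM.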

Compound 4, half-maximal inhibitory concentration: 500 nM
Estimate against measurement, compound 4: 1.3-fold (0.10 log units) below, within the range that was stated.
By their numbers in this assay, from the lowest: compounds 1, 2, 4 and 3 (each within the scatter of the next, the first and the last beyond it).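

In this assay, putting ((pyridin-3-yl)methyl)sulfanyl on the aromatic carbon between two ring nitrogen atoms gives a 1.2-fold higher number from compound 2 to compound 4 (0.06 log units; within the scatter), so this exchange of groups at this position causes no change beyond the scatter. The exchange alters two things at once, since the oxygen of the leaving group is gone and the six-membered aromatic ring now holds a nitrogen, and the step alone cannot separate the two. Nothing measured here explains why the number stays within the scatter.

The compounds shown leave open what each alteration does alone, which benzylsulfanyl, with its ring of carbon only and no oxygen, could help to separate. They also leave open whether this position tolerates a group without sulfur, such as a simple amine.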